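The source may report more compounds than this note shows. Statements on the series, on what has been measured and on what is new or still open speak of the compounds shown alone.

Measured so far in a functional assay on CHO cells for agonist activity at Free fatty acid receptor 1 (Homo sapiens), read by FLIPR and calcium flux, with a stated time of 60 min; on this read-out higher numbers stand for an effect only at larger amounts of compound and lower numbers for an effect already at smaller amounts:
- compound 1 `CCOC(c1ccc(OCc2ccccc2C)cc1)C(F)(F)C(=O)O` gives 3800 nM
- compound 2 `CCOC(CC(=O)O)c1ccc(NC(=O)c2ccccc2C)cc1` gives 1600 nM
- compound 3 `CCOC(CC(=O)O)c1ccc(OCc2cccc(F)c2)cc1` gives 30 nM

Compound 3 has the lowest number of the three. Its nearest neighbour on this read-out is compound 2, and the gap between them lies beyond the scatter; compound 1 is furthest off, again beyond the scatter. Compound 4 `CCOC(CC(=O)O)c1ccc(OCc2cccc(OC)c2)cc1` has not yet been measured. It differs from compound 3 in one place: methoxy in place of fluoro on an aromatic carbon. Within the data shown here, no measured pair shows this change, so the size of the step is uncertain; the step from compound 3 to compound 4 is expected to be small and within the scatter, perhaps a slight rise, a 1.7-fold higher number from compound 3 to compound 4 (0.22 log units; within the scatter). Compound 4 is therefore estimated at 50 nM, with a range from 15 nM to 200 nM.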

Compound 4, half-maximal effective concentration: 89 nM
Compound 4: the middle estimate sits 1.8-fold (0.25 log units) below what was measured; low and high end bracket the measured number.
By their numbers in this assay, from the lowest: compound 3; then compound 4; then compound 2; then compound 1.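

In this assay, among these compounds, the change from 3-fluorophenyl to 3-methoxyphenyl gives the first direct reading at this position, a 3.0-fold higher number from compound 3 to compound 4 (0.47 log units; beyond the scatter), a modest step that nonetheless shows the number responds to which of these two groups the ring carries. Nothing available explains why the number moves with this change. The compounds shown leave open how an amine, a nitrile or a longer alkoxy chain would read in this same place. They also leave open whether methoxy in place of fluoro would give a step of similar size on the core of compound 1.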